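One measured number and a swapped side chain

The source may hold more compounds than are shown below. What is called first, only, known or untested is meant among the compounds shown, and "the series" means these compounds.

Measured so far:
Compound 1 `OC[C@H]1O[C@@H](n2cnc3c(N4CCN(C5CCCCC5)CC4)ncnc32)[C@H](O)[C@@H]1O`: "not active" (no number reported)
Compound 2 `CC(C)c1ccc(Nc2ncnc3c2ncn3[C@@H]2O[C@H](CO)[C@@H](O)[C@H]2O)cc1`: 50000 nM

In a functional assay on MCF7 cells (Homo sapiens) for antiproliferative activity, read by sulforhodamine B assay, with a stated time of 72 h (on this read-out higher numbers stand for weaker inhibition and lower numbers for stronger inhibition), compound 2 stands alone with a number, at 50000 nM on the scale, while compound 1 gave "not active" (no number reported) and no figure. With a single number there is nothing to rank it against. Compound 3 `OC[C@H]1O[C@@H](n2cnc3c(NCCNc4ccccc4)ncnc32)[C@H](O)[C@@H]1O` keeps the shared core and changes one group (2-anilinoethyl in place of 4-isopropylphenyl on a nitrogen on an aromatic ring), with 2-anilinoethyl in place of 4-isopropylphenyl on a nitrogen on an aromatic ring. For the measured compounds named here, no measured step exists to size this swap, so compound 2 at 50000 nM is the only anchor for an expectation. The expected change (a 1.3-fold lower number from compound 2 to compound 3 (0.10 log units; within the scatter)) stays within the usual scatter, with no direction favoured. For compound 3 the estimated value is 40000 nM (expected range 12000 nM to 120000 nM), and a result without a number remains possible.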

Compound 3, half-maximal inhibitory concentration: > 100000 nM
Compound 3: only a limit was reported; the forecaster's own chance of this, stated with the estimate: 45%; middle value at least 2.5-fold (0.39 log units) from the limit.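

In this assay compound 3 gives > 100000 nM, which is a limit of the assay and not a number. For the compounds shown here, this is the first step that can be read at this position: putting 2-anilinoethyl in place of 4-isopropylphenyl, on a nitrogen on an aromatic ring, gives an at least 2.0-fold higher number from compound 2 to compound 3 (0.30 log units; that floor lies within the scatter), so the swap brought no sign of stronger inhibition even though both groups have the same heavy-atom count and one six-membered aromatic ring. The full size of the step stays unknown because it rests on a limit: the limit of > 100000 nM in this assay, at which 1 of the 3 values shown sits.

Going by these compounds alone, whether any group on this nitrogen can bring the number clearly down remains open, since compound 2 is the only compound here with a measured number. A benzyl group or a carboxylic acid at the end of the chain might behave differently, and the compounds shown cannot say how.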